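Swapping methyl for fluoro on the anilino ring

This account rests on a few compounds, and the source may have more. Where it says the series, first, only, none or still open, it means among the compounds named here.

Compound 2, with the structure `COC(=O)c1c(Nc2ccc(C)cc2)sc(C(=O)c2ccc(C)cc2)c1C`, was tested in a functional assay, with a stated time of 150 min, tested at 25 ug/mL (on this read-out higher numbers stand for a stronger effect at the one concentration tested and lower numbers for a weaker effect), and came back as "not active" (no number reported), so no number describes where it stands; all that is known is that it showed no effect worth reporting. Compound 1, with the structure `COC(=O)c1c(Nc2ccc(F)cc2)sc(C(=O)c2ccc(OC)cc2)c1C`, gives 20.2% in this assay, a modest reading that carries a fluoro on the anilino ring and a methoxy on the benzoyl ring rather than the two methyl groups of compound 2.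

Compound 3, with the structure `COC(=O)c1c(Nc2ccc(F)cc2)sc(C(=O)c2ccc(C)cc2)c1C`, has not yet been measured. The change from compound 2 to compound 3 is fluoro in place of methyl on an aromatic carbon. Compound 1 shows that a fluoro in this place sits in a compound with a small but reported effect, while compound 2 shows that two methyl groups sit in a compound with none.

A small step upward from compound 2 in this assay is expected, likely near the edge of the usual scatter rather than far beyond it. Compound 3 is estimated to give 12%, within a range from 0% to 28%.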

Compound 3, a percentage reported as activity, at one concentration (the size of the read-out at that concentration, not a potency): "not active" (no number reported)
The entry for compound 3 holds no number, and the estimate cannot be compared.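

Among these compounds, compound 2 and compound 3 both came back as "not active" in this assay, so neither has a number and no step between them can be read. Nothing measured here bears on this result. Going by these compounds, whether fluoro in place of methyl on the anilino ring changes the effect at all stays open.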